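The compounds below may be only part of what the source reports. "The series", "measured", "known", "first", "only" and "open" are said of these compounds alone.

Working notes on the series. Compound 1 `C#CCNC1CCc2c(SCCc3cccc(Cl)c3)cccc21` is the reference point for this step, yet in an ADME assay on isolated protein for inhibition of Amine oxidase [flavin-containing] B (Homo sapiens) (a higher number here means a weaker inhibitor, a lower number a stronger inhibitor), compound 1 gives "not determined" (no result reported), so no number places it on the scale. Going by the values given here, the same holds for the other members with a shared core: compound 2 `C#CCNC1CCc2c(SCc3ccccc3)cccc21` gives "not active" (no number reported) in this assay, with no number behind it either, while compound 3 `C#CCNC1CCc2c(SCc3ccc(C(F)(F)F)cc3)cccc21` gives 930 nM in this assay and is the only measured value of the set. The step from compound 1 to compound 4 `C#CCNC1CCc2c(SCCc3ccc(C)cc3)cccc21` changes the aryl group only: 4-methylphenyl in place of 3-chlorophenyl on a saturated chain carbon, two bonds along the chain from a sulfur. Among the compounds with values here, no measured pair shows this change or one like it, so nothing tells whether it moves the number or leaves it within the scatter. What is known is that an unsubstituted aryl in compound 2 gave no activity, whereas a substituted one in compound 3 gave a number. Compound 4 is therefore expected to give a measurable but moderate number, estimated at 1500 nM with a range from 300 nM to 8000 nM.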

Compound 4, half-maximal inhibitory concentration: 4520 nM
The estimate for compound 4 lay 3.0-fold (0.48 log units) below the measured number, and the stated range covers the measured number.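

In this assay compound 1 gives "not determined" (no result reported) and compound 4 gives 4520 nM so no step can be read between these two compounds. The compounds shown leave open whether 4-methylphenyl in place of 3-chlorophenyl moves the number at all. No evidence bears on this result.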